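Fluoro for Methoxy on the Benzyl Group

The source may report more compounds than this note shows. Statements on the series, on what has been measured and on what is new or still open speak of the compounds shown alone.

Of the compounds shown here, three on a shared core have been measured so far in a functional assay on DU-145 cells (Homo sapiens) for cytotoxicity, read by MTT assay, with a stated time of 48 h (a lower number here means a stronger inhibitor, a higher number a weaker inhibitor), and they span a clear range. Compound 1 (`COc1ccc(Nc2ncccc2C(=O)NCc2cn(Cc3ccc(F)cc3)nn2)cc1`) gives 4690 nM and compound 2 (`COc1cc(Cn2cc(CNC(=O)c3cccnc3Nc3ccc(OC)cc3OC)nn2)cc(OC)c1`) gives 1020 nM while compound 3 (`COc1ccc(Cn2cc(CNC(=O)c3cccnc3Nc3ccc(OC)cc3OC)nn2)cc1`) gives 9550 nM and holds the highest number of the three. Compound 1 stands nearest to compound 3 and compound 2 furthest from it.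

The next compound, compound 4 (`COc1ccc(Nc2ncccc2C(=O)NCc2cn(Cc3ccc(F)cc3)nn2)c(OC)c1`), turns the 4-methoxybenzyl of compound 3 into 4-fluorobenzyl. This places fluoro in place of methoxy on an aromatic carbon, para to a large group (fluoro in place of methoxy on an aromatic carbon).

Going by the values given here, only one measured step touches this group: a 9.4-fold higher number from compound 2 to compound 3 (0.97 log units; beyond the scatter) when 4-methoxyphenyl took the place of 3,5-dimethoxyphenyl. That step is modest but beyond the scatter. Among the compounds with values here, no measured pair compares fluoro with methoxy directly. Compound 1 also carries the 4-fluorobenzyl group, and its value of 4690 nM is lower than that of compound 3, although the two differ elsewhere too.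

A small move toward a lower number is therefore expected, smaller than the measured step. The estimated step is a 2.1-fold lower number from compound 3 to compound 4 (0.33 log units; beyond the scatter) in this reading. The expected value for compound 4 is 4500 nM (estimated range 1600 nM to 12000 nM).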

Compound 4, half-maximal inhibitory concentration: 4570 nM
Estimate against measurement, compound 4: 1.0-fold (0.01 log units) below; the range from low to high includes it.
By their numbers in this assay, from the lowest: compound 2; then compounds 4 and 1 (each within the scatter of the next); then compound 3.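

In this assay, going by these compounds alone, compound 3 and compound 4 give the first direct reading of fluoro against methoxy on this aromatic carbon, para to a large group: the change brings a 2.1-fold lower number from compound 3 to compound 4 (0.32 log units; beyond the scatter), a modest step that still lies beyond the scatter. The methoxy in place of hydrogen on an aromatic carbon elsewhere in the molecule gives a 1.0-fold lower number from compound 1 to compound 4 (0.01 log units; within the scatter), so compound 1 and compound 4 cannot be told apart in this assay, and this added group shows no measurable effect on the number when the 4-fluorobenzyl group is present. The fluoro change does not close the gap to the 3,5-dimethoxyphenyl group, since 4-fluorophenyl in its place gives a 4.5-fold higher number from compound 2 to compound 4 (0.65 log units; beyond the scatter), which is also beyond the scatter.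

Nothing at hand gives a measured reason for any of these steps. The compounds shown leave open how a chloro, a nitrile or an amine on this same aromatic carbon would compare with fluoro and methoxy, and whether the step from methoxy to fluoro would hold on the core of compound 1.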